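From Chloro to 4-Fluorophenyl on the Shared Core

A few compounds are considered here, and "the series" means these few. Any claim that something is new, unique, unknown or untested is made for them only; others in the source may bear on it.

For the measured compounds named here, in a functional assay on SK-OV-3 cells (Homo sapiens) for cytotoxicity (on this read-out higher numbers stand for weaker inhibition and lower numbers for stronger inhibition), compound 3 `O=C(CCCCCCc1nc2ccc(Cl)cc2[nH]1)NO` gives 320 nM, the lowest of the three numbers measured so far. Compound 1 `O=C(CCCCCCc1nc2ccccc2[nH]1)NO` gives 2700 nM, and compound 2 `O=C(CCCCCc1nc2ccccc2[nH]1)NO` gives 11000 nM. Compound 4 `O=C(CCCCCCc1nc2ccc(-c3ccc(F)cc3)cc2[nH]1)NO` differs from compound 3 in one place: 4-fluorophenyl in place of chloro on an aromatic carbon. The measured step that bears most closely on this change is an 8.4-fold lower number from compound 1 to compound 3 (0.93 log units; beyond the scatter), showing that what sits on this aromatic carbon can matter; a 4.1-fold higher number from compound 1 to compound 2 (0.61 log units; beyond the scatter) concerns the chain and bears little here. Going by the values given here, no measured compound carries a ring at that carbon, so the direction is uncertain. A step of a 1.3-fold lower number from compound 3 to compound 4 (0.11 log units; within the scatter) is expected, within the scatter or slightly lower. Compound 4 is estimated at 250 nM, with a range from 60 nM to 1200 nM.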

Compound 4, half-maximal inhibitory concentration: 1200 nM
Compound 4: the middle estimate sits 4.8-fold (0.68 log units) below what was measured; the range from low to high includes it.
By their numbers in this assay, from the lowest: compound 3; then compound 4; then compound 1; then compound 2.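

Replacing chloro with 4-fluorophenyl gives a 3.8-fold higher number from compound 3 to compound 4 (0.57 log units; beyond the scatter), so this aromatic carbon accepts a ring, but the number does not fall as far as it does with chloro. Measured against hydrogen at the same carbon, the ring still gives a 2.3-fold lower number from compound 1 to compound 4 (0.35 log units; beyond the scatter), so both groups lower the number, chloro by more. Nothing measured explains this difference. From the compounds shown here alone, it remains open whether plain phenyl, methyl or an amine at this carbon would fall nearer chloro or nearer 4-fluorophenyl. Whether either group would act the same way on the shorter chain of compound 2 is also unknown.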